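Aroyl variation on the imide carbonyl of the series

The compounds below may be only part of what the source reports. "The series", "measured", "known", "first", "only" and "open" are said of these compounds alone.

Compound 1 `CN(C(=O)NC(=O)c1ccc(Cl)cc1Cl)c1nc(C(F)(F)F)c(C(=O)N/N=C/c2ccc(C(F)(F)F)cc2)s1` gives 9.4 ug/mL in a functional assay on A549 cells (Homo sapiens) for inhibition, read by MTT assay, with a stated time of 72 h; a lower number here means a stronger inhibitor, a higher number a weaker inhibitor. Compound 2 `CN(C(=O)NC(=O)c1ccc(C(F)(F)F)cc1)c1nc(C(F)(F)F)c(C(=O)N/N=C/c2ccc(C(F)(F)F)cc2)s1` carries 4-(trifluoromethyl)phenyl in place of 2,4-dichlorophenyl on a carbonyl carbon, and in this assay compound 2 gives only a limit, > 100 ug/mL. That change is an at least 10-fold higher number from compound 1 to compound 2 (1.02 log units; beyond the scatter); compound 2 thus stands at the limit of > 100 ug/mL in this assay, at which 1 of the 2 values shown sits, the top of the range shown. Compound 3 `CN(C(=O)NC(=O)c1ccccc1F)c1nc(C(F)(F)F)c(C(=O)N/N=C/c2ccc(C(F)(F)F)cc2)s1` differs from compound 2 by 2-fluorophenyl in place of 4-(trifluoromethyl)phenyl on a carbonyl carbon. Within the data shown here, no measured step covers this change; only the step from compound 1 to compound 2 touches the same position. Compound 3 is expected at 40 ug/mL (range 8 ug/mL to 150 ug/mL), an estimated at least 2.5-fold lower number from compound 2 to compound 3 (0.39 log units; beyond the scatter), with a fair chance that only a limit is returned again.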

Compound 3, half-maximal inhibitory concentration: 5.68 ug/mL
Compound 3: the middle estimate sits 7.0-fold (0.85 log units) above what was measured; measured number below the stated range.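

In this assay, the position tolerates more than compound 2 alone suggested, since 2-fluorophenyl on this carbonyl carbon gives an at least 17-fold lower number from compound 2 to compound 3 (1.24 log units; beyond the scatter). With 2,4-dichlorophenyl as the reference, the same position gives a 1.7-fold lower number from compound 1 to compound 3 (0.22 log units; within the scatter), so these two aroyl groups read alike and only 4-(trifluoromethyl)phenyl stands apart among the three. Compound 2 remains a limit of the assay, not a number: the limit of > 100 ug/mL in this assay, at which 1 of the 3 values shown sits.

Still open, from the compounds shown here alone, is how an unsubstituted phenyl, a 4-fluorophenyl or a pyridyl ring would read on this carbonyl carbon. The three compounds therefore cannot separate the identity of the trifluoromethyl group from its ring position in accounting for compound 2.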